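The compounds below may be only part of what the source reports. "The series", "measured", "known", "first", "only" and "open" are said of these compounds alone.

Three compounds share one core and differ only in the group on an amine nitrogen in a ring: compound 1 `Cc1ccc(-c2c3c(nc(C)c2C(OC(C)(C)C)C(=O)O)CCN(CCCC2CCCC2)C3)cc1`, compound 2 `CC(=O)N1CCc2nc(C)c(C(OC(C)(C)C)C(=O)O)c(-c3ccc(C)cc3)c2C1` and compound 3 `CCCCCN1CCc2nc(C)c(C(OC(C)(C)C)C(=O)O)c(-c3ccc(C)cc3)c2C1`. In an ADME assay on MT2 cells (Homo sapiens) for cytotoxicity, read by XTT assay, with a stated time of 4 days (a lower number here means that less compound is tolerated, a higher number that more compound is tolerated), compound 1 reaches only the limit of the assay, > 40000 nM. In this assay compound 2 likewise gives only a limit, > 40000 nM. Compound 3 also stands at a limit in this assay, > 40000 nM. Where compound 3 stands relative to the other two cannot be read, because all three values sit at the same limit (the limit of > 40000 nM in this assay, at which 3 of the 3 values shown sit). For the same reason the steps a step that the two limits leave unreadable from compound 1 to compound 2, a step that the two limits leave unreadable from compound 1 to compound 3 and a step that the two limits leave unreadable from compound 2 to compound 3 are unreadable. Compound 4 `Cc1ccc(-c2c3c(nc(C)c2C(OC(C)(C)C)C(=O)O)CCN(c2cccc(-c4ccccc4)c2)C3)cc1` differs from compound 3 by 3-phenylphenyl in place of pentyl on an amine nitrogen in a ring. The measured steps bear on this change only in that no exchange of the group on this nitrogen has yet brought a value below the limit. Compound 4 is therefore expected to stay at the limit, with an estimated step that the limit leaves unreadable from compound 3 to compound 4 that should be none beyond the scatter. For compound 4 the estimated value is 50000 nM, expected between 25000 nM and 100000 nM.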

Compound 4, half-maximal cytotoxic concentration: > 40000 nM
Compound 4 was reported as a limit; the forecaster's own chance of this, stated with the estimate: 80%; the middle value lies beyond the limit too.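

In this assay compound 4 also gives only a limit, > 40000 nM. Among these compounds, no step linking compound 4 to compound 1, compound 2 or compound 3 can be read: the limit of > 40000 nM in this assay, at which 4 of the 4 values shown sit. The compounds shown leave open at what concentration any of them becomes cytotoxic, and whether the group on the amine nitrogen changes this.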